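From isobutyl to 3-methoxybenzyl

This account rests on a few compounds, and the source may have more. Where it says the series, first, only, none or still open, it means among the compounds named here.

In a functional assay on L02 cells (Homo sapiens) for inhibition, read by Griess assay, with stated times of 1 h and 24 h (on this read-out lower numbers stand for stronger inhibition and higher numbers for weaker inhibition), compound 1 (`CCCc1nn(C)c2c(NC3CC3)nc(CCc3cccnc3)nc12`) gives 564000 nM. Compound 2 (`COc1cc(/C=C/c2nc(O)nc(NC(C)C)n2)cc(OC)c1OC`) gives < 40000 nM, which is a limit of the assay. Compound 3 (`CC(C)CNc1nc(/C=C/c2ccccc2)nc2ccsc12`) gives > 1000000 nM, also a limit, and the largest figure of the three. Compound 4 (`COc1cccc(CNc2nc(/C=C/c3ccccc3)nc3ccsc23)c1`) carries 3-methoxyphenyl in place of isopropyl on a saturated chain carbon bound to a nitrogen on an aromatic ring. Among the compounds with values here, no measured pair shows what one such change does in this assay. Within the data shown here, a moderate step toward stronger inhibition is expected, an at least 2.5-fold lower number from compound 3 to compound 4 (0.39 log units; beyond the scatter), with compound 1 at 564000 nM as the only guide to the size. For compound 4 the estimated value is 400000 nM, within a range of 50000 nM to 2000000 nM.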

Compound 4, half-maximal inhibitory concentration: > 1000000 nM
Compound 4 gave a limit, no number; the forecaster's own chance of this, stated with the estimate: 35%; middle value at least 2.5-fold (0.39 log units) from the limit.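

No step can be read from compound 3 to compound 4, because in this assay the values of both compounds are limits, not numbers: the limit of > 1000000 nM in this assay, at which 2 of the 4 values shown sit.

The compounds shown leave open what 3-methoxyphenyl in place of isopropyl does to inhibition in this assay.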